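Cyclohexyl for Thiophenyl in an EP1 Antagonist Series

This account rests on a few compounds, and the source may have more. Where it says the series, first, only, none or still open, it means among the compounds named here.

Of the compounds shown here, two have been measured in a functional assay on cells for antagonist activity at prostaglandin E2 receptor EP1 subtype (Rattus norvegicus), read by fluorescence and calcium flux, with a stated time of 60 s; a lower number here means a stronger inhibitor, a higher number a weaker inhibitor. Compound 1 `O=C(O)c1cccc(Cc2c(-c3ccccc3)nn3cc(Br)ccc23)n1` gives 11 nM in this assay. Compound 2 `O=C(O)c1cccc(Cc2c(-c3cccs3)nn3cc(Cl)ccc23)n1` gives 1100 nM, the higher of the two numbers, a gap that lies well beyond the usual scatter. Compound 1 and compound 2 differ in two places at once, so the two values alone cannot say which change carries the gap. Compound 3 `O=C(O)c1cccc(Cc2c(C3CCCCC3)nn3cc(Cl)ccc23)n1` has not yet been measured. It differs from compound 2 in one place: cyclohexyl in place of thiophen-2-yl on an aromatic carbon. Among the compounds with values here, no measured pair shows this change, so there is no step to lean on. Compound 3 is expected to stay close to compound 2, with a step from compound 2 to compound 3 of a 1.4-fold higher number from compound 2 to compound 3 (0.13 log units; within the scatter), not beyond the scatter in either direction. The estimate for compound 3 in this assay is 1500 nM, within a range of 300 nM to 8000 nM.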

Compound 3, half-maximal inhibitory concentration: 1200 nM
Estimate against measurement, compound 3: 1.3-fold (0.10 log units) above; the range from low to high includes it.
By their numbers in this assay, from the lowest: compound 1; then compounds 2 and 3 (each within the scatter of the next).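

In this assay the change from thiophen-2-yl to cyclohexyl on the aromatic carbon next to the ring nitrogen gives a 1.1-fold higher number from compound 2 to compound 3 (0.04 log units; within the scatter) and so leaves the reading within the scatter. Within the data shown here, this is the first comparison here that differs in one place only, and it shows that with chlorine on the shared core, a five-membered aromatic ring with sulfur and a six-membered non-aromatic ring of carbon only read alike at this position. Nothing available gives a reason for this match.

Compound 1 at 11 nM differs from compound 2 and from compound 3 in two places, so the separate parts played by its phenyl group and its bromine remain unresolved. As far as these compounds go, how a methyl group or a piperidine ring would read at this position also remains open.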